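Furan-2-yl for 2-vinylphenyl: notes on the series

The source may report more compounds than this note shows. Statements on the series, on what has been measured and on what is new or still open speak of the compounds shown alone.

Measured in a functional assay on A-431 cells (Homo sapiens) for cytotoxicity (on this read-out higher numbers stand for an effect only at larger amounts of compound and lower numbers for an effect already at smaller amounts), so far:
- compound 1 `COC1=C(C)C(=O)/C(=C(O)/C=C/c2ccc(F)cc2)C(=O)C1(C)C` gives 4.1 ug/mL
- compound 2 `COC1=C(C)C(=O)/C(=C(O)/C=C/c2cc(C)cc(C)c2)C(=O)C1(C)C` gives 4 ug/mL
- compound 3 `C=Cc1ccccc1/C=C/C(O)=C1/C(=O)C(C)=C(OC)C(C)(C)C1=O` gives 2.6 ug/mL

On these numbers compound 3 cannot be separated from the other two compounds. Next is compound 4 `COC1=C(C)C(=O)/C(=C(O)/C=C/c2ccco2)C(=O)C1(C)C` with furan-2-yl in place of 2-vinylphenyl on a double-bonded chain carbon bound to a double-bonded chain carbon. Swaps at this same place give a 1.0-fold lower number from compound 1 to compound 2 (0.01 log units; within the scatter) and a 1.6-fold lower number from compound 1 to compound 3 (0.20 log units; within the scatter) and a 1.5-fold lower number from compound 2 to compound 3 (0.19 log units; within the scatter) and none leaves the scatter. Among the measured compounds shown here, no measured compound carries a five-membered ring, so that part is uncovered. In this assay no step beyond the scatter is therefore expected. The estimated step is a 1.3-fold higher number from compound 3 to compound 4 (0.12 log units; within the scatter) and no direction is claimed for it. Compound 4 is expected at an estimated 3.4 ug/mL (range 1.7 ug/mL to 7 ug/mL).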

Compound 4, concentration for half-maximal effect: 14.7 ug/mL
Estimate against measurement, compound 4: 4.3-fold (0.64 log units) below; measured number above the stated range.
By their numbers in this assay, from the lowest: compounds 3, 2 and 1 (each within the scatter of the next); then compound 4.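

In this assay this position is no longer flat: furan-2-yl gives a 5.7-fold higher number from compound 3 to compound 4 (0.75 log units; beyond the scatter) and also a 3.7-fold higher number from compound 2 to compound 4 (0.57 log units; beyond the scatter) and a 3.6-fold higher number from compound 1 to compound 4 (0.55 log units; beyond the scatter) in the same direction. Among the compounds shown here, the three substituted phenyl groups stayed within the scatter of one another, so the first step beyond it comes with the five-membered aromatic ring with 1 hetero atom. No measurement shown gives a reason for this step.

As far as these compounds go, whether the step goes with the ring size or with the ring oxygen stays open. Thiophen-2-yl and furan-3-yl at this place would separate the two.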